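The source may hold more compounds than are shown below. What is called first, only, known or untested is meant among the compounds shown, and "the series" means these compounds.

Compound 1 `C=CC(=O)Nc1cccc(-n2cnc3cnc(Nc4ccc(N5CCN(C(C)=O)C(C)C5)cc4)nc32)c1`: 24200 nM
Compound 2 `C=CC(=O)Nc1cccc(-n2cnc3cnc(Nc4ccc(N5CCN(S(C)(=O)=O)CC5)cc4OC)nc32)c1`: 21900 nM
Compound 3 `C=CC(=O)Nc1cccc(-n2cnc3cnc(Nc4ccc(N5CCN(C)CC5)cc4)nc32)c1`: 7550 nM

All three measured compounds share one core and were tested in a functional assay on Raji cells (Homo sapiens) for antiproliferative activity, read by CCK-8 assay, with a stated time of 48 h; a lower number here means a stronger inhibitor, a higher number a weaker inhibitor. Compound 1 gives the highest of the three numbers; compound 2 lies within the scatter of it, so the two show no real difference, while compound 3 sits furthest away, with the step of a 3.2-fold lower number from compound 1 to compound 3 (0.51 log units; beyond the scatter), a modest gain.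

The new compound is compound 4 `C=CC(=O)Nc1cccc(-n2cnc3cnc(Nc4ccc(OC)cc4)nc32)c1`. Relative to compound 1 it carries methoxy in place of 4-acetyl-3-methylpiperazin-1-yl on an aromatic carbon. Going by the values given here, the only measured step that bears on this position is the one from compound 1 to compound 3, where exchanging the same 4-acetyl-3-methylpiperazin-1-yl group for another ring gave a modest improvement. Methoxy is a much smaller group than either, and nothing among the measured compounds shows what such a small group does at this place. The expectation is therefore cautious: a small gain at most, of a size comparable to or below the step seen for compound 3, and possibly nothing beyond the scatter. Compound 4 is accordingly expected to give 15000 nM, with a likely range from 5000 nM to 45000 nM, which corresponds to an estimated step of a 1.6-fold lower number from compound 1 to compound 4 (0.21 log units; within the scatter).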

Compound 4, half-maximal inhibitory concentration: 31200 nM
Compound 4: the middle estimate sits 2.1-fold (0.32 log units) below what was measured; the measured number falls inside the stated range.
By their numbers in this assay, from the lowest: compound 3; then compounds 2, 1 and 4 (each within the scatter of the next).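

In this assay, methoxy on this aromatic carbon cannot be told apart from the 4-acetyl-3-methylpiperazin-1-yl group, with a 1.3-fold higher number from compound 1 to compound 4 (0.11 log units; within the scatter), so going from 10 heavy atoms and a six-membered non-aromatic ring to 2 heavy atoms and no ring leaves no real difference in this read-out. Against the 4-methylpiperazin-1-yl group, the exchange for methoxy does lie beyond the scatter, with a 4.1-fold higher number from compound 3 to compound 4 (0.62 log units; beyond the scatter), so the earlier gain of compound 3 cannot be credited to the mere removal of the 4-acetyl-3-methylpiperazin-1-yl group and belongs, among these compounds, to 4-methylpiperazin-1-yl itself. No measurement at hand accounts for this difference between the two replacements.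

As far as these compounds go, what remains open is which part of the 4-methylpiperazin-1-yl group matters: the whole ring, or the methyl-bearing nitrogen alone. A morpholin-4-yl group, an unsubstituted piperazin-1-yl group or an open-chain dimethylamino group on the same aromatic carbon would help separate these possibilities, and the compounds shown do not say how any of them would behave.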